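Series notes: lengthening the chain that carries the piperazine

The compounds below may be only part of what the source reports. "The series", "measured", "known", "first", "only" and "open" are said of these compounds alone.

Of the compounds shown here, three have been measured in a functional assay on BCG823 cells (Homo sapiens) for antiproliferative activity, read by MTT assay, with a stated time of 48 h; a lower number here means a stronger inhibitor, a higher number a weaker inhibitor. Compound 3 `COc1cc2oc(-c3ccccc3)cc(=O)c2c(O)c1OCCCN1CCN(C)CC1` gives 31300 nM. Compound 1 `COc1cc2oc(-c3ccccc3)cc(=O)c2c(O)c1OCCCCN1CCN(C)CC1` gives 53500 nM. Compound 2 `CN1CCN(CCCOc2c(OCc3ccccc3)cc3oc(-c4ccccc4)cc(=O)c3c2O)CC1` gives 4100 nM and stands lowest of the three, with its step to compound 3 beyond the scatter a 7.6-fold higher number from compound 2 to compound 3 (0.88 log units; beyond the scatter). The difference between compound 3 and compound 2 is phenyl in place of hydrogen on a saturated chain carbon bound to an oxygen on an aromatic ring.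

Compound 4 `CN1CCN(CCCCOc2c(OCc3ccccc3)cc3oc(-c4ccccc4)cc(=O)c3c2O)CC1` has not yet been measured in this assay. It differs from compound 2 by (4-methylpiperazin-1-yl)methyl in place of 4-methylpiperazin-1-yl on a saturated chain carbon, three bonds along the chain from an oxygen on an aromatic ring. The same change has already been made once in the series, from compound 3 to compound 1, where it reads ((4-methylpiperazin-1-yl)methyl in place of 4-methylpiperazin-1-yl on a saturated chain carbon, three bonds along the chain from an oxygen on an aromatic ring); the place is described in the same words for both pairs, so this is the same change on a different core. That earlier step was a 1.7-fold higher number from compound 3 to compound 1 (0.23 log units; within the scatter), which lies within the scatter, so on the core of compound 3 the lengthening of the chain by one carbon left the read-out essentially unchanged.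

For the measured compounds named here, for compound 4 a step of a 1.7-fold higher number from compound 2 to compound 4 (0.23 log units; within the scatter) from compound 2 is expected, resting on the one earlier instance a 1.7-fold higher number from compound 3 to compound 1 (0.23 log units; within the scatter) and on the value of compound 2 4100 nM. Going by the values given here, the estimate for compound 4 in this assay is 7000 nM, with a range from 2500 nM to 20000 nM, the width reflecting that only one prior instance of the change is available and the core differs.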

Compound 4, half-maximal inhibitory concentration: 7200 nM
Compound 4: the middle estimate sits 1.0-fold (0.01 log units) below what was measured; the range from low to high includes it.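

In this assay, putting (4-methylpiperazin-1-yl)methyl in place of 4-methylpiperazin-1-yl on the core carrying the phenyl gives a 1.8-fold higher number from compound 2 to compound 4 (0.24 log units; within the scatter), and this step agrees with the one on the core of compound 3: the same change on two cores in this assay, a 1.7-fold higher number (0.23 log units; within the scatter) from compound 3 to compound 1 and a 1.8-fold higher number (0.24 log units; within the scatter) from compound 2 to compound 4, 1.0-fold (0.01 log units) apart, within the scatter of two such steps. The other change, phenyl in place of hydrogen on a saturated chain carbon bound to an oxygen on an aromatic ring, gives a 7.4-fold lower number from compound 1 to compound 4 (0.87 log units; beyond the scatter), beyond the scatter, and it carries over with nearly the same size from one chain to the other: the same change on two cores in this assay, a 7.6-fold higher number (0.88 log units; beyond the scatter) from compound 2 to compound 3 and a 7.4-fold higher number (0.87 log units; beyond the scatter) from compound 4 to compound 1, 1.0-fold (0.01 log units) apart, within the scatter of two such steps. Within these four compounds the two changes therefore combine without visible interference, but the chain step stays within the scatter on both cores, so what carries over is the absence of a clear effect, and the evidence rests on a single pair of cores in a single cell line.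

Going by these compounds, it remains open whether the same agreement would hold for a shorter chain such as 2-(4-methylpiperazin-1-yl)ethyl or a longer one such as 5-(4-methylpiperazin-1-yl)pentyl. On these data alone, it is equally open whether a morpholine in place of the 4-methylpiperazine, or a substituted benzyl in place of the plain one, would keep the step seen with phenyl.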